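The source may report more compounds than this note shows. Statements on the series, on what has been measured and on what is new or still open speak of the compounds shown alone.

Working notes on the series. Three compounds have been run in a functional assay on Jurkat cells for inhibition of nuclear factor NF-kappa-B complex (Homo sapiens); a higher number here means a weaker inhibitor, a lower number a stronger inhibitor. Compound 1 `CCOC(=O)c1cnc(-c2csc(C)n2)nc1NN1C(=O)C=C(C)C1=O` gives 8000 nM in this assay, and compound 2 `CCOC(=O)c1cnc(-c2cccc(OC)c2)nc1NN1C(=O)C=C(C)C1=O` gives 5000 nM. For the measured compounds named here, the only single-point step among the measured compounds is a 1.6-fold lower number from compound 1 to compound 2 (0.20 log units; within the scatter), which is no more than scatter. Compound 3 `CC1=CC(=O)N(Nc2nc(-c3cccs3)ncc2-c2cc(C)no2)C1=O`, which carries a different pair of substituents and a 3-methyl-1,2-oxazol-5-yl group, gives 300 nM in this assay, the lowest number of the three, with compound 2 and compound 1 both well above it, beyond the scatter.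

Compound 4 `CC1=CC(=O)N(Nc2nc(-c3cccs3)ncc2-c2nc(C)co2)C1=O` is not yet measured. It differs from compound 3 only in the ring joined to the shared core: 4-methyl-1,3-oxazol-2-yl in place of 3-methyl-1,2-oxazol-5-yl on an aromatic carbon. The two groups are built from the same atoms and match in their counts of donors and acceptors.

Going by the values given here, no measured step touches this position; the one step known, from compound 1 to compound 2, lies elsewhere on the core and was within scatter. So the step is expected to be small, with no clear direction: estimated as a 1.5-fold higher number from compound 3 to compound 4 (0.18 log units; within the scatter). Compound 4 is therefore expected to give about 450 nM in this assay, with a likely range from 150 nM to 1500 nM.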

Compound 4, half-maximal inhibitory concentration: 200 nM
Beside the measured number, compound 4's estimate is 2.3-fold (0.35 log units) above it; the measured number falls inside the stated range.
By their numbers in this assay, from the lowest: compounds 4 and 3 (each within the scatter of the next); then compounds 2 and 1 (each within the scatter of the next).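

Replacing 3-methyl-1,2-oxazol-5-yl with 4-methyl-1,3-oxazol-2-yl on this aromatic carbon, para to the thiophen-2-yl group, gives a 1.5-fold lower number from compound 3 to compound 4 (0.18 log units; within the scatter) in this assay. For the compounds shown here, this is the first step read at this position, and it shows that here the same atoms can be joined differently into another five-membered aromatic ring without a difference that rises above the scatter, so this pair of rings cannot be told apart in this assay. Nothing at hand bears on the reason for this result.

Both rings compared here are methyl-bearing five-membered aromatic rings with 2 hetero atoms, so the compounds shown leave open how this position responds to a group of another kind, such as a carboxylic acid, a primary amide or a dimethylamino group. They also leave open how much of the gap between the two compounds with an oxazole-type ring and the ethyl esters, compound 1 and compound 2, belongs to this position, since those compounds differ from compound 3 and compound 4 in more than one place.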